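A few compounds are considered here, and "the series" means these few. Any claim that something is new, unique, unknown or untested is made for them only; others in the source may bear on it.

Compound 1 `CCn1c(/C=C2/C(=O)Nc3ccc(C)cc32)nc2ccccc21` and compound 2 `CCn1c(/C=C2/C(=O)Nc3ccc(Br)cc32)nc2ccccc21` share one core and differ at a single aromatic carbon. In a functional assay on DU-145 cells (Homo sapiens) for cytotoxicity, read by MTT assay, with a stated time of 48 h (a higher number here means a weaker inhibitor, a lower number a stronger inhibitor), compound 1 gives 39300 nM, and compound 2 gives 45800 nM. The step of a 1.2-fold higher number from compound 1 to compound 2 (0.07 log units; within the scatter) leaves the two within the scatter of each other, so compound 2 stands level with compound 1 on the numbers shown. Compound 3 `CCn1c(/C=C2/C(=O)Nc3ccc([N+](=O)[O-])cc32)nc2ccccc21` differs from compound 2 by nitro in place of bromo on an aromatic carbon. Within the data shown here, only the step from compound 1 to compound 2 bears on this change, and it stayed within the scatter, so no step beyond the scatter is expected in this assay. Compound 3 is therefore estimated at 45000 nM, with a range from 15000 nM to 135000 nM, an expected step of a 1.0-fold lower number from compound 2 to compound 3 (0.01 log units; within the scatter).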

Compound 3, half-maximal inhibitory concentration: > 50000 nM
Compound 3 gave a limit, no number; the forecaster's own chance of this, stated with the estimate: 15%; middle value at least 1.1-fold (0.04 log units) from the limit.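

Among the groups shown at this place on the six-membered aromatic ring, only nitro leaves a limit and not a number: in this assay compound 3 gives > 50000 nM, which is a limit of the assay. Its steps can be read only as floors: an at least 1.0-fold higher number from compound 2 to compound 3 (0.03 log units; that floor lies within the scatter), and an at least 1.2-fold higher number from compound 1 to compound 3 (0.10 log units; that floor lies within the scatter). Nitro in place of bromo or methyl therefore brings no lower number here, while the true distance of compound 3 from the other two stays unknown. Going by these compounds, whether an amine or a carboxylic acid at this place, or a longer chain elsewhere on the shared core, would give a lower number remains open.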